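Methoxy to ethoxy on compound 3

The compounds below may be only part of what the source reports. "The series", "measured", "known", "first", "only" and "open" are said of these compounds alone.

- compound 1 `C=C(Br)C(=O)Nc1cccc(/C=C/C(=O)Nc2ccccc2)c1`: 16600 nM
- compound 2 `C=C(Br)C(=O)Nc1cccc(/C=C/C(=O)Nc2ccc(Cl)cc2)c1`: 7900 nM
- compound 3 `C=C(Br)C(=O)Nc1cccc(/C=C/C(=O)Nc2ccc(OC)cc2)c1`: 2300 nM

These values come from a functional assay on HT-29 cells (Homo sapiens) for inhibition, read by MTT assay, with a stated time of 72 h; a lower number here means a stronger inhibitor, a higher number a weaker inhibitor. Among the three compounds, compound 3 has the lowest number at 2300 nM, which makes it the strongest inhibitor so far. Compound 4 `C=C(Br)C(=O)Nc1cccc(/C=C/C(=O)Nc2ccc(OCC)cc2)c1` differs from it in one place: methyl in place of hydrogen on a saturated chain carbon bound to an oxygen on an aromatic ring. This is methyl in place of hydrogen on a saturated chain carbon bound to an oxygen on an aromatic ring, so methoxy becomes ethoxy.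

Within the data shown here, no measured step makes this exact change. The closest evidence comes from swapping the group on the aromatic carbon: a 2.1-fold lower number from compound 1 to compound 2 (0.32 log units; beyond the scatter), a 7.2-fold lower number from compound 1 to compound 3 (0.86 log units; beyond the scatter) and a 3.4-fold lower number from compound 2 to compound 3 (0.54 log units; beyond the scatter). All three steps are modest, and each replaces the whole group. The new change keeps the oxygen and adds only a methyl, so a smaller step is expected in this assay, probably none beyond the scatter, and the data give no firm direction. The expected change is a 1.1-fold higher number from compound 3 to compound 4 (0.04 log units; within the scatter). For compound 4 the estimated value is 2500 nM, with an expected range from 1100 nM to 5500 nM.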

Compound 4, half-maximal inhibitory concentration: 3400 nM
Beside the measured number, compound 4's estimate is 1.4-fold (0.13 log units) below it, and the stated range covers the measured number.
By their numbers in this assay, from the lowest: compounds 3 and 4 (each within the scatter of the next); then compound 2; then compound 1.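

In this assay the added methyl gives a 1.5-fold higher number from compound 3 to compound 4 (0.17 log units; within the scatter) and so cannot be told apart from the scatter, which means that methoxy and ethoxy cannot be separated here, and that this saturated chain carbon bound to the oxygen accepts one extra methyl without a readable change. Ethoxy also keeps the distance from the two earlier groups, with a 2.3-fold lower number from compound 2 to compound 4 (0.37 log units; beyond the scatter) against chloro and a 4.9-fold lower number from compound 1 to compound 4 (0.69 log units; beyond the scatter) against hydrogen, so among these four compounds both groups that attach through oxygen give lower numbers than chloro or hydrogen, a contrast that until now rested on methoxy alone. Nothing measured on these compounds accounts for this difference or for the flat step from methoxy to ethoxy.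

As far as these compounds go, with only one added methyl to go on, it remains open how far the chain can grow, and whether a propoxy or butoxy group, or a branched isopropoxy group, would still match methoxy and ethoxy. From the compounds shown here alone, it is also open whether the oxygen itself matters, which a hydroxyl, a dimethylamino group or a plain ethyl group on the same aromatic carbon could begin to show.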